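Phenoxy added to the phenyl group of compound 1

A few compounds are considered here, and "the series" means these few. Any claim that something is new, unique, unknown or untested is made for them only; others in the source may bear on it.

In a functional assay on KB 3-1 cells (Homo sapiens) for cytotoxicity, read by MTT assay, with a stated time of 72 h (a lower number here means a stronger inhibitor, a higher number a weaker inhibitor), compound 1 (`O=C1Nc2ccccc2/C1=N/NC(=S)Nc1ccccc1`) gives 3530 nM and stands lowest of the three numbers. Compound 2 (`O=C1Nc2ccccc2/C1=N/NC(=S)NC1CCCCC1`) gives 9140 nM and compound 3 (`C=CCNC(=S)N/N=C1\C(=O)Nc2ccccc21`) gives 26100 nM in the same test. The change to compound 4 (`O=C1Nc2ccccc2/C1=N/NC(=S)Nc1ccc(Oc2ccccc2)cc1`) is phenoxy in place of hydrogen on an aromatic carbon and puts phenoxy in place of hydrogen on an aromatic carbon. Within the data shown here, two measured steps bear on it only indirectly: cyclohexyl in place of phenyl gave a 2.6-fold higher number from compound 1 to compound 2 (0.41 log units; beyond the scatter) and allyl in place of phenyl gave a 7.4-fold higher number from compound 1 to compound 3 (0.87 log units; beyond the scatter) on the amide-type nitrogen. Among the measured compounds shown here, no measured step tests a substituent on that aromatic ring. The estimated step is a 2.0-fold lower number from compound 1 to compound 4 (0.29 log units; within the scatter) and is expected to be modest. The expected value for compound 4 is 1800 nM within an estimated range from 500 nM to 6000 nM in this assay terms.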

Compound 4, half-maximal inhibitory concentration: 5720 nM
The estimate for compound 4 lay 3.2-fold (0.50 log units) below the measured number; the measured number falls inside the stated range.
By their numbers in this assay, from the lowest: compounds 1, 4 and 2 (each within the scatter of the next, the first and the last beyond it); then compound 3.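

Phenoxy on an aromatic carbon, para to a large group, is the first substituent on this ring among the compounds shown. In this assay it gives a 1.6-fold higher number from compound 1 to compound 4 (0.21 log units; within the scatter), so a group of this size at this place leaves the number within the scatter of compound 1, whereas replacing the phenyl group outright in compounds 2 and 3 gave steps beyond it. No available evidence bears on this result.

The compounds shown leave open how an amine or a carboxylic acid would read at this place. From the compounds shown here alone, whether phenoxy on another carbon of this ring would also stay within the scatter of compound 1 is equally open.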